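Replacing furan-2-yl with phenyl on an aromatic carbon

This account rests on a few compounds, and the source may have more. Where it says the series, first, only, none or still open, it means among the compounds named here.

In a functional assay on VCaP cells (Homo sapiens) for antiproliferative activity, read by CCK-8 assay, with a stated time of 6 days (on this read-out lower numbers stand for stronger inhibition and higher numbers for weaker inhibition), compound 1 `CCN(c1ccc(C#N)c(Cl)c1)c1cc(-c2ccncc2)ccc1C` gives 2900 nM. For compound 2 `CCN(c1cccc(-c2ccccc2)c1)c1ccc(C#N)c(Cl)c1` the entry reads "not determined" (no result reported). Compound 3 `CCN(c1ccc(C#N)c(Cl)c1)c1cc(-c2ccco2)ccc1C` reaches only a limit of the assay, > 30000 nM. Compound 4 `CCN(c1ccc(C#N)c(Cl)c1)c1cc(-c2ccccc2)ccc1C` carries phenyl in place of furan-2-yl on an aromatic carbon. Going by the values given here, one measured step bears on this carbon, with furan-2-yl in place of pyridin-4-yl, and it is large: an at least 10-fold higher number from compound 1 to compound 3 (1.01 log units; beyond the scatter). Compound 1, at 2900 nM, holds a six-membered aromatic ring there, as phenyl is, so a partial return toward stronger inhibition seems likely. The expected step is an at least 3.3-fold lower number from compound 3 to compound 4 (0.52 log units; beyond the scatter). For compound 4 the estimated value is 9000 nM, with an expected range of 2500 nM to 30000 nM.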

Compound 4, half-maximal inhibitory concentration: > 30000 nM
Compound 4: no number, only a limit; the forecaster's own chance of this, stated with the estimate: 25%; middle value at least 3.3-fold (0.52 log units) from the limit.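

In this assay compound 4 gives > 30000 nM, which is a limit of the assay and not a number. Phenyl in place of pyridin-4-yl brings an at least 10-fold higher number from compound 1 to compound 4 (1.01 log units; beyond the scatter), so a six-membered aromatic ring alone does not keep the activity at this carbon, and of the compounds with a reported result, only compound 1, with pyridin-4-yl, gives a number. The step between furan-2-yl and phenyl cannot be read, because compound 3 and compound 4 both stand at the limit: the limit of > 30000 nM in this assay, at which 2 of the 4 values shown sit.

Still open, from the compounds shown here alone, is whether the nitrogen of pyridin-4-yl is what counts here. Pyridin-3-yl, or a phenyl carrying an amine, at this carbon would bear on that.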